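Series notes: pyrrolidin-2-yl to 1-methylpyrrolidin-2-yl

A few compounds are considered here, and "the series" means these few. Any claim that something is new, unique, unknown or untested is made for them only; others in the source may bear on it.

Measured so far:
compound 1 `Cc1ccc2[nH]c(C(=O)N[C@H]3CN(S(=O)(=O)c4ccccc4)C[C@@H]3C(=O)NCCN(C)C)cc2c1`: 16 uL/min
compound 2 `Cc1ccc2[nH]c(C(=O)N[C@H]3CN(S(=O)(=O)c4ccccc4)C[C@@H]3C(=O)NC[C@H]3CCCN3)cc2c1`: 10 uL/min

In an ADME assay on cells (Hepatocyte, Rattus norvegicus) for metabolic stability (on this read-out lower numbers stand for slow clearance and higher numbers for fast clearance), compound 2 holds the lowest of the two numbers, with compound 1 nearest; the step of a 1.6-fold lower number from compound 1 to compound 2 (0.20 log units; within the scatter) separates them, and it lies within the scatter, so the two compounds cannot be ordered on this read-out.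

Compound 3 `Cc1ccc2[nH]c(C(=O)N[C@H]3CN(S(=O)(=O)c4ccccc4)C[C@@H]3C(=O)NC[C@@H]3CCCN3C)cc2c1` is the next member. It differs from compound 2 by 1-methylpyrrolidin-2-yl in place of pyrrolidin-2-yl on a saturated chain carbon bound to an amide-type nitrogen. Among the measured compounds shown here, the only measured step, a 1.6-fold lower number from compound 1 to compound 2 (0.20 log units; within the scatter), concerns the same place in the molecule but exchanges a different pair of groups, so it bears on the present change only as a rough guide; it showed that a change at this place left the number within the scatter. The step from compound 2 to compound 3 is therefore expected to be small, a 1.2-fold higher number from compound 2 to compound 3 (0.08 log units; within the scatter), in no firm direction. Compound 3 is expected to give about 12 uL/min, with a range from 6 uL/min to 24 uL/min.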

Compound 3, intrinsic clearance in a liver preparation (reported as CLH), per the amount of preparation that the assay uses: 23 uL/min
Compound 3: middle estimate off by 1.9-fold (0.28 log units), on the low side; measured number inside the range.
By their numbers in this assay, from the lowest: compounds 2, 1 and 3 (each within the scatter of the next, the first and the last beyond it).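

In this assay, among the compounds shown here, the change from pyrrolidin-2-yl to 1-methylpyrrolidin-2-yl gives the first step beyond the scatter at this place on a saturated chain carbon bound to an amide-type nitrogen, a 2.3-fold higher number from compound 2 to compound 3 (0.36 log units; beyond the scatter), so this place is not neutral for every exchange. For the compounds shown here, the same place still does not separate (dimethylamino)methyl from 1-methylpyrrolidin-2-yl, a 1.4-fold higher number from compound 1 to compound 3 (0.16 log units; within the scatter), and the one group with a hydrogen-bond donor, pyrrolidin-2-yl, differs beyond the scatter only from 1-methylpyrrolidin-2-yl. No supporting measurement accounts for the step.

The compounds shown leave open whether the step follows the loss of the hydrogen-bond donor or the added methyl. A 1-ethylpyrrolidin-2-yl or piperidin-2-yl group in the same place would test how far the step extends beyond this single pair.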